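Indole-urea series: removing the 2-chlorobenzyl group

The source may report more compounds than this note shows. Statements on the series, on what has been measured and on what is new or still open speak of the compounds shown alone.

Compound 1 `CCN(CC)Cc1ccc2nc(NC(=O)N/N=C/c3cn(Cc4ccccc4Cl)c4ccccc34)sc2c1` is the single numbered entry in the set. In a functional assay on MDA-MB-231 cells (Homo sapiens) for cytotoxicity, read by MTT assay, with a stated time of 72 h (on this read-out higher numbers stand for weaker inhibition and lower numbers for stronger inhibition), compound 1 gives 900 nM. Within the data shown here, a second entry, compound 2 `CCN(CC)Cc1ccc2nc(NC(=O)N/N=C3\C(=O)Nc4ccc(F)cc43)sc2c1`, differs in the hydrazone portion, and for compound 2 the result in this assay stands as "not determined" (no result reported), so no number is available for comparison and compound 1 holds the only measured value.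

The next compound, compound 3 `CCN(CC)Cc1ccc2nc(NC(=O)N/N=C/c3c[nH]c4ccccc34)sc2c1`, is made from compound 1 by one change: hydrogen in place of 2-chlorobenzyl on an aromatic nitrogen. Among the measured compounds shown here, no pair of measured compounds in the set shows what such a change does, so the direction of the step rests on the single value of compound 1 and on the size of the group removed.

Expectation: a step in this assay somewhat beyond the usual scatter, towards weaker inhibition, is estimated from compound 1 to compound 3, that is a 2.4-fold higher number from compound 1 to compound 3 (0.39 log units; beyond the scatter). For compound 3 the expected value is 2200 nM, with a range from 600 nM to 8000 nM.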

Compound 3, half-maximal inhibitory concentration: 1900 nM
The estimate for compound 3 lay 1.2-fold (0.06 log units) above the measured number, within the range that was stated.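

Among these compounds, the step on this aromatic nitrogen is the first measured at this position: in this assay hydrogen in place of 2-chlorobenzyl gives a 2.1-fold higher number from compound 1 to compound 3 (0.32 log units; beyond the scatter), a modest change that lies beyond the usual scatter. The 2-chlorobenzyl group, with its six-membered aromatic ring of carbon and its chlorine, is therefore not essential for a measurable effect, since compound 3 , with no heavy atom on this nitrogen, still gives 1900 nM in the same read-out. No measurement in hand offers an explanation for this step.

Among the compounds shown here, the single step does not separate the contribution of the chlorine from that of the rest of the benzyl group: an unsubstituted benzyl or a methyl group on the same aromatic nitrogen would divide the step between those parts. Also open, on these data alone, is how a longer chain ending in an amine or a carboxylic acid at this nitrogen would compare with the 2-chlorobenzyl group of compound 1 and the hydrogen of compound 3 in this cell-based read-out.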